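The compounds below may be only part of what the source reports. "The series", "measured", "known", "first", "only" and "open" are said of these compounds alone.

Of the compounds shown here, three have been measured in an assay on HEK293 cells for binding affinity to 5-hydroxytryptamine receptor 7 (Homo sapiens), read by radioligand binding; a lower number here means a stronger inhibitor, a higher number a weaker inhibitor. Compound 1 `Brc1ccc2ccn(CCN3CCN4CCCCC4C3)c2c1` gives 70 nM, compound 2 `CN1CCCN(CCn2ccc3cc(Br)ccc32)CC1` gives 88 nM, and compound 3 `CN1CCCN(CCn2ccc3ccc(Cl)cc32)CC1` gives 34 nM. Compound 3 thus carries the lowest of the three numbers; its gap to compound 1 and its gap to compound 2 both lie beyond the scatter, so among these three it is the strongest binder on record.

The step that follows leads from compound 3 to compound 4 `C#Cc1ccc2ccn(CCN3CCCN(C)CC3)c2c1`, which has not yet been measured. The structural change is ethynyl in place of chloro on an aromatic carbon; everything else in compound 3 is kept unchanged. Among the measured compounds shown here, no pair of measured compounds shows an exchange of this kind, so there is no measured step to lean on, and the expectation rests on the change alone. A small halogen gives way to a small linear two-carbon group at the same position, and the expected step is a 1.3-fold higher number from compound 3 to compound 4 (0.12 log units; within the scatter), which is not beyond the scatter in either direction, with at most a slight lean toward a higher number.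

For compound 4 the estimate in this assay is 45 nM, with a range from 15 nM to 140 nM.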

Compound 4, inhibition constant: 140 nM
For compound 4 the middle estimate is 3.1-fold (0.49 log units) below the measured one; low and high end bracket the measured number.
By their numbers in this assay, from the lowest: compound 3; then compounds 1, 2 and 4 (each within the scatter of the next).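

In this assay, replacing chloro with ethynyl on this aromatic carbon, meta to a fused ring and para to a fused ring, is not a neutral exchange: a 4.1-fold higher number from compound 3 to compound 4 (0.61 log units; beyond the scatter) is a step beyond the scatter, toward weaker binding. Among the compounds shown here, the earlier compounds could not show this, since no two of them differ in one place, so this is the first direct sign that the number in this assay responds to the group held at this position, with the rest of the molecule unchanged. Nothing at hand bears on why a two-carbon ethynyl group fares worse here than a single chlorine atom.

The compounds shown leave open how a nitrile, a methoxy group or a plain hydrogen would fare on this same carbon, and so whether the step is particular to ethynyl or follows from replacing chloro with any other group. They also leave open whether the same exchange would give a step of like size with the side chain of compound 1 in place of the one kept here.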